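One Aryl Swap Judged From Three Quiet Neighbours

The compounds below may be only part of what the source reports. "The series", "measured", "known", "first", "only" and "open" are said of these compounds alone.

Three compounds have so far been tested in a functional assay on MCF7 cells (Homo sapiens) for inhibition, read by MTT assay, with a stated time of 48 h; a higher number here means a weaker inhibitor, a lower number a stronger inhibitor:

Compound 1 `COc1ccc(/C=N/NC(=O)CSc2nnc(-c3ccncc3)n2-c2ccccc2)cc1` gives 23700 nM.
Compound 2 `O=C(CSc1nnc(-c2ccncc2)n1-c1ccccc1)N/N=C/c1ccc([N+](=O)[O-])cc1` gives 15300 nM.
Compound 3 `O=C(CSc1nnc(-c2ccncc2)n1-c1ccccc1)N/N=C/c1ccc(F)cc1` gives 12300 nM.

All three share the same core and differ only in the group on the aromatic ring that hangs from the carbon with a double bond to nitrogen. Compound 3 stands at the smallest number of the three, yet the steps of a 1.9-fold lower number from compound 1 to compound 3 (0.28 log units; within the scatter) and a 1.2-fold lower number from compound 2 to compound 3 (0.09 log units; within the scatter) are both within the scatter, and the step of a 1.5-fold lower number from compound 1 to compound 2 (0.19 log units; within the scatter) is as well, so the three cannot be told apart on these numbers.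

Compound 4 `O=C(CSc1nnc(-c2ccncc2)n1-c1ccccc1)N/N=C/c1cc(Br)ccc1O` has not yet been measured. It differs from compound 3 as follows: 5-bromo-2-hydroxyphenyl in place of 4-fluorophenyl on a carbon with a double bond to nitrogen. The three measured steps bear on this change only loosely: they show that swapping one group for another on this ring, whether methoxy, nitro or fluoro, moved the number within the scatter each time. For the measured compounds named here, no measured compound carries a hydroxyl or a bromine on this ring, so the new pattern has no direct precedent here.

On that basis, no step beyond the scatter is expected from compound 3 to compound 4, and the estimated change is a 1.2-fold lower number from compound 3 to compound 4 (0.09 log units; within the scatter). Compound 4 is therefore expected to give about 10000 nM in this assay, with a range from 3000 nM to 35000 nM.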

Compound 4, half-maximal inhibitory concentration: 6460 nM
Beside the measured number, compound 4's estimate is 1.5-fold (0.19 log units) above it; low and high end bracket the measured number.
By their numbers in this assay, from the lowest: compounds 4, 3, 2 and 1 (each within the scatter of the next, the first and the last beyond it).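

In this assay, for the compounds shown here, this position now gives steps beyond the scatter, with a 2.4-fold lower number from compound 2 to compound 4 (0.37 log units; beyond the scatter) and a 3.7-fold lower number from compound 1 to compound 4 (0.56 log units; beyond the scatter) both modest in size, which no step among the first three compounds did. The step of a 1.9-fold lower number from compound 3 to compound 4 (0.28 log units; within the scatter) stays within the scatter, however, so at this place 5-bromo-2-hydroxyphenyl can be told apart from 4-nitrophenyl and 4-methoxyphenyl but not from 4-fluorophenyl. No supporting measurement is at hand that would explain the separation from those two groups.

The entering group brings the hydroxyl and the bromine together, and no compound shown carries only one of them on this ring, so the share of each in these steps stays open. Also open, as far as these compounds go, is how this ring would read with an amine or a carboxylic acid on it, and whether either would move the number further than the steps seen so far.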